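A Methyl Added to a Compound at the Assay Limit

The source may hold more compounds than are shown below. What is called first, only, known or untested is meant among the compounds shown, and "the series" means these compounds.

Compound 1 (`C[C@H](/N=C(\S)Nc1ccccn1)c1cccc2ccccc12`): in a functional assay on RBL-2H3 cells (Rattus norvegicus) for inhibition (a lower number here means a stronger inhibitor, a higher number a weaker inhibitor), compound 1 gives > 100000 nM, a limit of the assay rather than a number.
Compound 2 (`Cc1cccc2sc(N/C(S)=N/[C@H](C)c3cccc4ccccc34)nc12`): in this assay compound 2 gives > 100000 nM, again a limit and not a number.

Compound 1 thus stands only at the limit of > 100000 nM in this assay, at which 2 of the 2 values shown sit, so no measured number places it. The two measured compounds are not related by a single change, and their two limits show only that neither inhibits within the range of the assay. Compound 3 (`Cc1cccc(N/C(S)=N/[C@@H](C)c2cccc3ccccc23)n1`) has not yet been measured. It differs from compound 1 by methyl in place of hydrogen on an aromatic carbon; cut one bond further out, pyridin-2-yl becomes 6-methylpyridin-2-yl. Among the compounds with values here, no step between measured compounds is available to size this change. With compound 1 sitting at the limit, the expected step in this assay is none beyond the scatter, that is a number no higher from compound 1 to compound 3 (the limit leaves the size open). Compound 3 is expected to give 100000 nM, within 30000 nM to 300000 nM, most likely reported again as a limit.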

Compound 3, half-maximal inhibitory concentration: 1600 nM
The estimate for compound 3 lay 63-fold (1.80 log units) above the measured number, outside the stated range (below it).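

Until now the compounds shown gave only limits, so nothing showed that this series could register inhibition at all. In this assay, putting methyl in place of hydrogen on the aromatic carbon next to the ring nitrogen, which turns pyridin-2-yl into 6-methylpyridin-2-yl, gives an at least 62-fold lower number from compound 1 to compound 3 (1.79 log units; beyond the scatter), so this single position can carry a compound from the limit to a measured number. The true size of the step stays open, since one end of it is only a limit: the limit of > 100000 nM in this assay, at which 2 of the 3 values shown sit.

As far as these compounds go, whether methyl itself matters here remains open: an ethyl group, a chlorine atom or a methoxy group at this position would show whether other groups do the same. Methyl placed elsewhere on the ring would show whether the gain belongs to this position alone.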